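This account rests on a few compounds, and the source may have more. Where it says the series, first, only, none or still open, it means among the compounds named here.

Measured so far, in an ADME assay on PC-3 cells (Homo sapiens) for cytotoxicity, read by CCK-8 assay, with a stated time of 6 days; a higher number here means a weaker inhibitor, a lower number a stronger inhibitor:
Compound 1 `C[C@@H](Cn1ccc(-c2ccc(C#N)c(Cl)c2)n1)NC(=O)c1ccccc1` gives > 30000 nM, which is a limit of this assay rather than a number.
Compound 2 `CC(=O)c1ccc(C(=O)N[C@@H](C)Cn2ccc(-c3ccc(C#N)c(Cl)c3)n2)cc1` gives > 30000 nM, again a limit of this assay rather than a number.

Compound 2 therefore stands only at a limit on the numbers shown, and the one other value shown is a limit as well. For the measured compounds named here, the single measured step, a step that the two limits leave unreadable from compound 1 to compound 2, cannot be read in size because of the limit of > 30000 nM in this assay, at which 2 of the 2 values shown sit. The compound still to be measured, compound 3 `COc1ccc(C(=O)N[C@@H](C)Cn2ccc(-c3ccc(C#N)c(Cl)c3)n2)cc1`, differs from compound 2 by methoxy in place of acetyl on an aromatic carbon. Going by the values given here, the only measured step concerns a change at that same aromatic carbon, yet it gives no readable size, so there is no measured basis for a direction. With both values shown sitting at the limit, compound 3 is expected to sit there as well. The expected step of a number no higher from compound 2 to compound 3 (the limit leaves the size open) is none beyond the scatter. Compound 3 is estimated at 30000 nM, in the range 10000 nM to 100000 nM, most likely reported as a limit once more.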

Compound 3, half-maximal inhibitory concentration: > 30000 nM
Compound 3: a limit, no number (the forecaster's own chance of this, stated with the estimate: 85%); the middle value lies on the limit itself.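

In this assay compound 3 gives > 30000 nM which is again a limit and not a number. For the compounds shown here, compound 1, compound 2 and compound 3 all sit at that same limit, so no step among them can be read. The compounds shown leave open whether hydrogen, acetyl or methoxy on that aromatic carbon makes any difference to the value.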